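This account rests on a few compounds, and the source may have more. Where it says the series, first, only, none or still open, it means among the compounds named here.

Values so far in an ADME assay on liver for metabolic stability, with Liver microsome (Homo sapiens) as the target, read by LC-MS, using microsomes; a higher number here means faster removal of the compound, a lower number slower removal:
- compound 1 (`CC(C)(C)OC[C@@H](O)C(=O)N1[C@H](C(=O)NCc2cc(Cl)ccc2-n2cnnn2)C[C@@H]2C[C@@H]21`) gives 21 mL.min-1.g-1
- compound 2 (`CC1(C[C@@H](O)C(=O)N2N=CC[C@H]2C(=O)NCc2cc(Cl)ccc2-n2cnnn2)CC1`) gives < 12 mL.min-1.g-1
- compound 3 (`CC(C)(C)[C@@H](O)C(=O)N1CSC[C@H]1C(=O)NCc1cc(Cl)ccc1-n1cnnn1`) gives 120 mL.min-1.g-1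

In this assay compound 2 reports < 12 mL.min-1.g-1 as a limit of the assay, not a number. Compound 4 (`O=C(NCc1cc(Cl)ccc1-n1cnnn1)[C@@H]1CC=NN1C(=O)[C@H](O)C1CCCCC1`) carries cyclohexyl in place of (1-methylcyclopropyl)methyl on a saturated chain carbon bound to a carbonyl carbon and an oxygen on a saturated carbon. Compound 1 gives 21 mL.min-1.g-1 and compound 3 gives 120 mL.min-1.g-1 but both differ from compound 2 in more than one place, so they offer only a loose guide. A small rise in this assay is expected (an at least 1.6-fold higher number from compound 2 to compound 4 (0.22 log units; that floor lies within the scatter)), perhaps no more than the usual scatter. The estimated value for compound 4 is 20 mL.min-1.g-1 (expected range 12 mL.min-1.g-1 to 45 mL.min-1.g-1).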

Compound 4, intrinsic clearance in microsomes: 63 mL.min-1.g-1
Estimate against measurement, compound 4: 3.2-fold (0.50 log units) below; the whole stated range lies below it.
By their numbers in this assay, from the lowest: compound 1; then compounds 4 and 3 (each within the scatter of the next). At a limit, below all of these: compound 2.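

This is the only pair shown that differs in one place: in this assay, cyclohexyl in place of (1-methylcyclopropyl)methyl on a saturated chain carbon bound to a carbonyl carbon and an oxygen on a saturated carbon gives an at least 5.2-fold higher number from compound 2 to compound 4 (0.72 log units; beyond the scatter). A change at this one place, with the shared core kept, is thus enough to move the number beyond the scatter. The true step could be larger because compound 2 stands at a limit of the assay: the limit of < 12 mL.min-1.g-1 in this assay, at which 1 of the 4 values shown sits.

Going by these compounds, it remains open whether a cyclopentyl or tetrahydropyranyl group here would stay nearer compound 2 or compound 4. The same swap on another core is also untested by these compounds.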